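The source may report more compounds than this note shows. Statements on the series, on what has been measured and on what is new or still open speak of the compounds shown alone.

In a functional assay on the whole organism with Rattus norvegicus as the target (on this read-out lower numbers stand for an effect already at smaller amounts and higher numbers for an effect only at larger amounts of compound), compound 1 `CCCNc1cc(OC)c(C(=O)NC2CCN(Cc3ccccc3)C2)cc1Cl` gives 17 mg/kg. Compound 2 `COc1cc(NCc2ccccc2)c(Cl)cc1C(=O)NC1CCN(Cc2ccccc2)C1` gives > 30 mg/kg, which is a limit of the assay and not a number. Among the compounds with values here, the step between them, an at least 1.7-fold higher number from compound 1 to compound 2 (0.24 log units; that floor lies within the scatter), also concerns a group on the nitrogen on an aromatic ring, so it is the only measured guide here.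

Compound 3 `COc1cc(NC(C)=O)c(Cl)cc1C(=O)NC1CCN(Cc2ccccc2)C1` differs from compound 2 by having acetyl in place of benzyl on that nitrogen, a change from benzylamino to acetamido (acetyl in place of benzyl on a nitrogen on an aromatic ring). Within the data shown here, no measured step covers this exchange directly, and the one available step cannot be told apart from scatter. Among the measured compounds shown here, no large step in this assay is therefore expected, and the assay may again report only a limit. The expected outcome is an at least 1.2-fold lower number from compound 2 to compound 3 (0.07 log units; that floor lies within the scatter). The estimated value for compound 3 is 25 mg/kg, with an expected range of 9 mg/kg to 70 mg/kg.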

Compound 3, dose for half-maximal effect: 1.8 mg/kg
The estimate for compound 3 lay 14-fold (1.14 log units) above the measured number; the whole stated range lies above it.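

Within the data shown here, on the nitrogen on an aromatic ring, the choice of group matters far more in this assay than the earlier compounds could show: acetyl in place of benzyl gives an at least 16-fold lower number from compound 2 to compound 3 (1.22 log units; beyond the scatter), and acetyl in place of propyl gives a 9.4-fold lower number from compound 1 to compound 3 (0.98 log units; beyond the scatter). Both steps lie beyond the scatter, whereas the step from propyl to benzyl did not clearly do so, and of the three groups shown only acetyl brings a carbonyl to this nitrogen. Compound 2 gives a limit of the assay and not a number, so the first step is only a floor: the limit of > 30 mg/kg in this assay, at which 1 of the 3 values shown sits.

The compounds shown cannot tell whether the carbonyl itself counts or some other feature of acetyl. As far as these compounds go, how a free amine, a propanoyl group or a methanesulfonyl group on this nitrogen would compare also stays open.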